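Dog liver microsomes: swapping the indole for a benzylamine

A few compounds are considered here, and "the series" means these few. Any claim that something is new, unique, unknown or untested is made for them only; others in the source may bear on it.

Two compounds sharing one core have been run in an ADME assay on microsomes from liver (Canis lupus familiaris) for metabolic stability, read by LC-MS, tested at 0.5 uM; on this read-out lower numbers stand for slow clearance and higher numbers for fast clearance. Compound 1 `CCCCN(C(=O)c1ccc(C(F)(F)F)cc1)c1nnc(-c2ccc(S(=O)(=O)NCCC(=O)O)cc2)s1` gives 596 uL/min in this assay. Compound 2 `CCCCN(C(=O)c1ccc(C(F)(F)F)cc1)c1nnc(-c2ccc(F)c3[nH]ccc23)s1` gives 464 uL/min in this assay. On these two numbers compound 2 stands beside compound 1, the gap between them lying within the usual scatter, so nothing separates the two in this assay.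

Compound 3 `CCCCN(C(=O)c1ccc(C(F)(F)F)cc1)c1nnc(-c2ccc(CN(C)C)cc2)s1` has not yet been measured in this assay. It differs from compound 2 in one place: a group of 10 heavy atoms (9 carbon, 1 nitrogen; one six-membered aromatic ring of carbon only) in place of a group of 10 heavy atoms (8 carbon, 1 nitrogen, 1 fluorine; one five-membered aromatic ring with 1 hetero atom, one six-membered aromatic ring of carbon only), on an aromatic carbon. Within the data shown here, no step between measured compounds bears on this change, so the expectation can rest only on the two values in hand.

Because compound 1 gives 596 uL/min and compound 2 gives 464 uL/min in this assay, both at the fast end of clearance, compound 3 is expected to stay in the same region, with a step of a 1.1-fold higher number from compound 2 to compound 3 (0.03 log units; within the scatter) that would not exceed the scatter. The estimate for compound 3 in this assay is 500 uL/min, with a range from 230 uL/min to 1100 uL/min.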

Compound 3, intrinsic clearance in a liver preparation (reported as CLH), per the amount of preparation that the assay uses: 1150 uL/min
Compound 3: middle estimate off by 2.3-fold (0.36 log units), on the low side; measured number outside the range, above it.
By their numbers in this assay, from the lowest: compounds 2, 1 and 3 (each within the scatter of the next, the first and the last beyond it).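

In this assay, placing the 4-((dimethylamino)methyl)phenyl group on the shared core in place of the two-ring group of compound 2 gives a 2.5-fold higher number from compound 2 to compound 3 (0.39 log units; beyond the scatter) and so a modest step beyond the scatter, which shows that the clearance number can move with the group at this position. The same group set against compound 1, with (dimethylamino)methyl in place of (2-carboxyethyl)sulfamoyl on the phenyl ring, gives a 1.9-fold higher number from compound 1 to compound 3 (0.29 log units; within the scatter) and stays within the scatter, so compound 1 and compound 3 cannot be told apart despite carrying very different substituents. Nothing available here bears on why the number moves at this position.

The step from compound 2 changes the ring system and adds the amine at once, so these compounds leave open which of the two carries the difference, a question that a plain phenyl ring or an indole bearing a (dimethylamino)methyl group at this position could address. Going by these compounds, it also remains open whether the number depends on the amine itself, as a morpholine, a primary amine or a longer chain between the amine and the phenyl ring in place of the (dimethylamino)methyl group could show.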